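The compounds below may be only part of what the source reports. "The series", "measured", "known", "first", "only" and "open" are said of these compounds alone.

Measured in a functional assay on MDA-MB-231 cells (Homo sapiens) for cytotoxicity, read by MTT assay, with a stated time of 72 h; on this read-out higher numbers stand for weaker inhibition and lower numbers for stronger inhibition
- compound 1 (`O=C1c2c[n+]([O-])c3ccccc3c2C(=O)c2c1c1ccccc1n2CCCCn1ccnc1`) gives 210 nM
- compound 2 (`O=C1c2c[n+]([O-])c3ccccc3c2C(=O)c2c1c1ccccc1n2Cc1cn(CC(O)CO)nn1`) gives 1290 nM
- compound 3 (`O=C1c2c[n+]([O-])c3ccccc3c2C(=O)c2c1c1ccccc1n2CCN1CCCC1`) gives 630 nM

Compound 3 holds the middle place of the three values, with a 2.0-fold lower number from compound 2 to compound 3 (0.31 log units; beyond the scatter) on one side and a 3.0-fold higher number from compound 1 to compound 3 (0.48 log units; beyond the scatter) on the other. The change to compound 4 (`O=C1c2c[n+]([O-])c3ccccc3c2C(=O)c2c1c1ccccc1n2CCCCN1CCNCC1`) is 2-(piperazin-1-yl)ethyl in place of pyrrolidin-1-yl on a saturated chain carbon, two bonds along the chain from an aromatic nitrogen and it sits on a saturated chain carbon, two bonds along the chain from an aromatic nitrogen. Among the compounds with values here, no measured step makes this exact swap. The closest evidence is the second step above, which sits at the same place, with pyrrolidin-1-yl replacing 2-(1H-imidazol-1-yl)ethyl, and it is modest. The largest step, a 6.1-fold higher number from compound 1 to compound 2 (0.79 log units; beyond the scatter) in size, involves a triazole-bearing group and bears less directly. A small move toward a lower number in this assay is therefore expected, probably not beyond the scatter. The expected change is a 1.6-fold lower number from compound 3 to compound 4 (0.20 log units; within the scatter) as estimated here. For compound 4 the estimated value is 400 nM (expected range 130 nM to 1200 nM).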

Compound 4, half-maximal inhibitory concentration: 3310 nM
Compound 4: middle estimate off by 8.3-fold (0.92 log units), on the low side, outside the stated range (above it).
By their numbers in this assay, from the lowest: compound 1; then compound 3; then compound 2; then compound 4.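

In this assay the step at this place runs upward, with a 5.3-fold higher number from compound 3 to compound 4 (0.72 log units; beyond the scatter) when 2-(piperazin-1-yl)ethyl replaces pyrrolidin-1-yl, and compound 4 now has the highest number of the four, also against the triazole-bearing compound 2 (a 2.6-fold higher number from compound 2 to compound 4 (0.41 log units; beyond the scatter)). The largest step in the series is a 16-fold higher number from compound 1 to compound 4 (1.20 log units; beyond the scatter), a pair that differs only in the end group, piperazin-1-yl in place of 1H-imidazol-1-yl, four bonds along the chain from an aromatic nitrogen, so a change of end group alone can move the number this far on that chain. No measurement at hand accounts for this rise.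

The shown pairs do not separate the effect of the end ring from that of chain length in the step from compound 3 to compound 4. A morpholin-4-yl or 4-methylpiperazin-1-yl end group on the same chain would show whether the ring's second nitrogen and its hydrogen track with the higher number.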